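The source may hold more compounds than are shown below. What is called first, only, known or untested is meant among the compounds shown, and "the series" means these compounds.

- Compound 1 `Cc1ccc(-n2cc(COc3cccc4cnc(Nc5cccc(Cl)c5)nc34)nn2)c([N+](=O)[O-])c1` 4000 nM
- Compound 2 `Clc1cccc(Nc2ncc3cccc(OCc4cn(Cc5c(Cl)cccc5Cl)nn4)c3n2)c1` 6000 nM
- Compound 3 `COc1cccc(-n2cc(COc3cccc4cnc(Nc5cccc(Cl)c5)nc34)nn2)c1` 8000 nM

In a functional assay on MCF7 cells (Homo sapiens) for cytotoxicity, read by cell counting, with a stated time of 48 h (a lower number here means a stronger inhibitor, a higher number a weaker inhibitor), compound 3 gives 8000 nM, and its steps to the other two compounds stay within the scatter: a 2.0-fold higher number from compound 1 to compound 3 (0.30 log units; within the scatter) and a 1.3-fold higher number from compound 2 to compound 3 (0.12 log units; within the scatter). Compound 4 `Clc1cccc(Nc2ncc3cccc(OCc4cn(-c5cc(Cl)cc(Cl)c5)nn4)c3n2)c1` has 3,5-dichlorophenyl in place of 3-methoxyphenyl on an aromatic nitrogen. The measured steps at this same nitrogen bear on the change: besides those two, there is a 1.5-fold higher number from compound 1 to compound 2 (0.18 log units; within the scatter). None of the three goes beyond the scatter, so no step beyond the scatter is expected in this assay. The expected outcome is a 1.3-fold lower number from compound 3 to compound 4 (0.12 log units; within the scatter). Compound 4 is estimated at 6000 nM, with an expected range of 2500 nM to 15000 nM.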

Compound 4, half-maximal inhibitory concentration: 5000 nM
Estimate against measurement, compound 4: 1.2-fold (0.08 log units) above; measured number inside the range.
By their numbers in this assay, from the lowest: compounds 1, 4, 2 and 3 (each within the scatter of the next).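

In this assay, 3,5-dichlorophenyl, with no hydrogen-bond acceptor, replaces 3-methoxyphenyl, with one, on the aromatic nitrogen and gives a 1.6-fold lower number from compound 3 to compound 4 (0.20 log units; within the scatter), so losing that acceptor produces no readable change. The comparisons with the other groups, a 1.2-fold lower number from compound 2 to compound 4 (0.08 log units; within the scatter) and a 1.3-fold higher number from compound 1 to compound 4 (0.10 log units; within the scatter), also stay within the scatter, leaving all four groups at this position indistinguishable. No measured evidence accounts for this result. From the compounds shown here alone, whether any group at this nitrogen can move the number beyond the scatter remains open. An amine or a carboxylic acid on the phenyl ring would test that.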